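This account rests on a few compounds, and the source may have more. Where it says the series, first, only, none or still open, it means among the compounds named here.

Going by the values given here, compound 2 `COc1cc(-c2cc(/C=C/C(=O)c3ccc(N)cc3)[nH]n2)cc(OC)c1OC` is one of two compounds measured in a functional assay on SK-MEL-5 cells (Homo sapiens) for cytotoxicity, read by sulforhodamine B assay, with a stated time of 48 h, tested at 100 uM; on this read-out lower numbers stand for a stronger effect and higher numbers for a weaker effect at the one concentration tested. In this assay compound 2 gives -94%, the higher of the two numbers on record, although the gap to its neighbour is within the scatter. Compound 1 `COc1ccc(-c2cc(/C=C/C(=O)c3ccc(N)cc3)[nH]n2)cc1` in this assay gives -100%, so the two cannot be told apart. Compound 3 `COc1ccc(-c2cc(/C=C/C(=O)c3ccc(N)cc3)[nH]n2)cc1OC` differs from compound 2 in one place: hydrogen in place of methoxy on an aromatic carbon. Among the compounds with values here, with no step between measured compounds to guide it, this change is expected to move this assay by no more than the scatter, in no particular direction. Compound 3 is therefore estimated at -95%, between -110% and -70%, and the expected step of a number 1 percentage points lower from compound 2 to compound 3 (within the scatter) stays within the scatter.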

Compound 3, a percentage reported as activity, at one concentration (the size of the read-out at that concentration, not a potency): -94%
Compound 3: middle estimate off by 1 percentage points, on the low side; the range from low to high includes it.
By their numbers in this assay, from the lowest: compounds 1, 2 and 3 (each within the scatter of the next).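

In this assay, hydrogen in place of methoxy on an aromatic carbon gives no change at the digits printed from compound 2 to compound 3 (within the scatter) and methoxy in place of hydrogen on an aromatic carbon gives a number 6 percentage points higher from compound 1 to compound 3 (within the scatter) at this position and the one it was exchanged with. Exchanging methoxy and hydrogen on this ring therefore does not separate these compounds at the one concentration tested. No measured evidence explains this result. Going by these compounds, whether a hydroxyl, an amine or a chlorine on this ring would read differently remains open. So does whether these compounds would separate at lower concentrations.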